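Three measured compounds and a methylsulfonyl replacement

This account rests on a few compounds, and the source may have more. Where it says the series, first, only, none or still open, it means among the compounds named here.

Compound 1 `CN(C)c1ccc(C2CC(c3ccc(-n4cncn4)cc3)=NN2)cc1` — 7%
Compound 2 `CN(C)c1ccc(C2CC(c3ccc(-n4cncn4)cc3)=NN2C(=O)c2cc(Cl)cc(Cl)c2)cc1` — 9.4%
Compound 3 `CN(C)c1ccc(C2CC(c3ccc(-n4cncn4)cc3)=NN2C(=O)/C=C/c2ccccc2)cc1` — 8.5%

Of the compounds shown here, three have been tested in a functional assay on MDA-MB-231 cells (Homo sapiens) for inhibition, read by sulforhodamine B assay, tested at 10 uM; a higher number here means more inhibition at the concentration tested (going by the name of the read-out), a lower number less inhibition. Compound 1 gives 7%, compound 2 gives 9.4% and compound 3 gives 8.5%. Compound 3 stands second highest of these three numbers, but its separation from either neighbour is small: a number 0.9 percentage points lower from compound 2 to compound 3 (within the scatter) and a number 1.5 percentage points higher from compound 1 to compound 3 (within the scatter). Likewise a number 2.4 percentage points higher from compound 1 to compound 2 (within the scatter). All three values therefore sit within the usual scatter of one another, and no order among them can be read.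

Compound 4 `CN(C)c1ccc(C2CC(c3ccc(-n4cncn4)cc3)=NN2S(C)(=O)=O)cc1` is the next structure to be measured. (methylsulfonyl in place of (2-phenylethenyl)carbonyl on an amine nitrogen in a ring). The measured steps that bear on this change all alter the group on the same ring nitrogen: a number 2.4 percentage points higher from compound 1 to compound 2 (within the scatter) and a number 1.5 percentage points higher from compound 1 to compound 3 (within the scatter) replaced a hydrogen there with two different carbonyl groups, and a number 0.9 percentage points lower from compound 2 to compound 3 (within the scatter) exchanged one carbonyl substituent for another. None of these moved the number beyond the scatter. A methylsulfonyl group on that nitrogen has not been tried, so the expectation rests on the observation that varying this position has so far changed little. The resulting step is therefore expected to be no larger than the scatter, a number 0.5 percentage points lower from compound 3 to compound 4 (within the scatter). For compound 4 the estimated value in this assay is 8%, with a range from -2% to 18%.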

Compound 4, a percentage reported as inhibition, at one concentration (the size of the read-out at that concentration, not a potency): 7.8%
The estimate for compound 4 lay 0.2 percentage points above the measured number, and the stated range covers the measured number.
By their numbers in this assay, from the lowest: compounds 1, 4, 3 and 2 (each within the scatter of the next).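

In this assay, replacing either carbonyl group on the amine nitrogen in the ring with methylsulfonyl gives a number 0.7 percentage points lower from compound 3 to compound 4 (within the scatter) and a number 1.6 percentage points lower from compound 2 to compound 4 (within the scatter), so a sulfonyl link and a substituent with no ring leave the number within the scatter of those carrying a carbonyl link and a six-membered aromatic ring of carbon only. Measured against hydrogen on the same nitrogen, methylsulfonyl gives a number 0.8 percentage points higher from compound 1 to compound 4 (within the scatter), which places hydrogen, both carbonyl groups and methylsulfonyl within the scatter of one another at this position. Nothing available gives a reason for this lack of separation.

The compounds shown leave open whether a group carrying an amine or a carboxylic acid on that ring nitrogen would move the number beyond the scatter. They also leave open what replacing the 4-(dimethylamino)phenyl group or the 4-(1H-1,2,4-triazol-1-yl)phenyl group would do, since both stay the same across all four compounds.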